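This account rests on a few compounds, and the source may have more. Where it says the series, first, only, none or still open, it means among the compounds named here.

Working notes on the series. Compound 3 `Cc1cc(Cl)cc(-c2ccnc3cc(CN4C(=O)C5C(C4=O)C5(C)C)sc23)c1O[C@@H]1CCNC[C@@H]1C` stands second highest of the three numbers in an assay on RKO cells for inhibition of ubiquitin carboxyl-terminal hydrolase 7 (Homo sapiens), read by a luciferase reporter, with a stated time of 18 h; on this read-out higher numbers stand for an effect only at larger amounts of compound and lower numbers for an effect already at smaller amounts: compound 3 gives 65 nM, while compound 1 `Cc1cc(Cl)cc(-c2ccnc3cc(CN4C(=O)C5C(C4=O)C5(C)C)sc23)c1C[C@@H]1CNCCO1` gives 25 nM and compound 2 `Cc1cc(Cl)cc(-c2ccnc3cc(CN4C(=O)CCC4=O)sc23)c1O[C@H]1CCCNC1` gives 180 nM. Among the compounds with values here, the only single-point step measured so far, a 2.6-fold higher number from compound 1 to compound 3 (0.41 log units; beyond the scatter), concerns the group on the aromatic carbon and not the imide, so it bears only indirectly on the step now considered.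

Compound 4 `Cc1cc(Cl)cc(-c2ccnc3cc(CN4C(=O)CCC4=O)sc23)c1O[C@@H]1CCNC[C@@H]1C` differs from compound 3 by a group of 7 heavy atoms (4 carbon, 1 nitrogen, 2 oxygen; one five-membered non-aromatic ring with 1 hetero atom) in place of a group of 10 heavy atoms (7 carbon, 1 nitrogen, 2 oxygen; one three-membered non-aromatic ring of carbon only, one five-membered non-aromatic ring with 1 hetero atom), on a saturated chain carbon bound to an aromatic carbon. Within the data shown here, no measured pair isolates this change. Compound 2 carries the same 2,5-dioxopyrrolidin-1-yl group, but differs from compound 3 in the amine as well, so its value can only hint that the number rises when the smaller imide is present.

On this basis compound 4 is expected to give a higher number than compound 3 in this assay, a step of a 2.3-fold higher number from compound 3 to compound 4 (0.36 log units; beyond the scatter), modest to clear. The estimate for compound 4 is 150 nM, with a range from 60 nM to 400 nM.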

Compound 4, half-maximal effective concentration: 150 nM
Beside the measured number, compound 4's estimate shows no gap at the digits printed, and the stated range covers the measured number.
By their numbers in this assay, from the lowest: compound 1; then compound 3; then compounds 4 and 2 (each within the scatter of the next).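

In this assay, 2,5-dioxopyrrolidin-1-yl in place of the group of 10 heavy atoms with its three-membered ring, on a saturated chain carbon bound to an aromatic carbon, gives a 2.3-fold higher number from compound 3 to compound 4 (0.36 log units; beyond the scatter), and this is the only pair shown that isolates this change with the amine held fixed. With 2,5-dioxopyrrolidin-1-yl held fixed, 3-methylpiperidin-4-yl in place of piperidin-3-yl on an oxygen on an aromatic ring gives a 1.2-fold lower number from compound 2 to compound 4 (0.08 log units; within the scatter), so the numbers of these two compounds cannot be told apart. Nothing at hand explains either step.

Open, on these data alone, is whether the step follows the three-membered ring or its two methyl groups, which a 3,3-dimethyl-2,5-dioxopyrrolidin-1-yl group would help separate. Also open, as far as these compounds go, is whether the same step appears with the (morpholin-2-yl)methyl group of compound 1.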